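The source may report more compounds than this note shows. Statements on the series, on what has been measured and on what is new or still open speak of the compounds shown alone.

Compound 1 `O=C(/C=C/c1ccccc1)Nc1ccc2ncnc(Nc3cccc(Br)c3)c2c1`: 1.45 ug/mL
Compound 2 `O=C(/C=C/c1ccccc1Cl)Nc1ccc2ncnc(Nc3cccc(Br)c3)c2c1`: 2 ug/mL

Both numbers come from a functional assay on B16-F10 cells (Mus musculus) for inhibition, read by MTT assay, with a stated time of 48 h; on this read-out higher numbers stand for weaker inhibition and lower numbers for stronger inhibition. Compound 2 stands at the top of these two numbers, but the step of a 1.4-fold higher number from compound 1 to compound 2 (0.14 log units; within the scatter) lies within the scatter, so the two compounds are not truly apart. Compound 3 `Cc1ccc(/C=C/C(=O)Nc2ccc3ncnc(Nc4cccc(Br)c4)c3c2)cc1` differs from compound 2 by 4-methylphenyl in place of 2-chlorophenyl on a double-bonded chain carbon bound to a double-bonded chain carbon. For the measured compounds named here, the only measured step that bears on swapping a group on this ring, a 1.4-fold higher number from compound 1 to compound 2 (0.14 log units; within the scatter), was small, so the expected change from compound 2 to compound 3 is a 1.2-fold lower number from compound 2 to compound 3 (0.07 log units; within the scatter), with no direction beyond the scatter. Compound 3 is therefore estimated at 1.7 ug/mL, ranging from 0.8 ug/mL to 3.6 ug/mL.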

Compound 3, half-maximal inhibitory concentration: 1.39 ug/mL
Estimate against measurement, compound 3: 1.2-fold (0.09 log units) above; the measured number falls inside the stated range.
By their numbers in this assay, from the lowest: compounds 3, 1 and 2 (each within the scatter of the next).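

In this assay, replacing 2-chlorophenyl with 4-methylphenyl gives a small shift (a 1.4-fold lower number from compound 2 to compound 3 (0.16 log units; within the scatter)), and adding methyl to the unsubstituted phenyl of the core gives a smaller one still (a 1.0-fold lower number from compound 1 to compound 3 (0.02 log units; within the scatter)). This ring has now carried a chloro or a methyl group with no step beyond the scatter. (No measurement here gives a reason for these numbers)

The chloro and methyl groups also sit in different places, so the effects of group and place cannot be separated. As far as these compounds go, whether an amine or a carboxylic acid on this ring would move the number beyond the scatter stays open.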